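The source may hold more compounds than are shown below. What is called first, only, known or untested is meant among the compounds shown, and "the series" means these compounds.

Among the compounds with values here, compound 2 `O=C1C=C(NCc2ccccc2)C(=O)c2c1nc1n2[C@H]2OC[C@@H](O)[C@H]2OC1` gives 2670 nM in a functional assay on MGC-803 cells (Homo sapiens) for inhibition, read by sulforhodamine B assay (a lower number here means a stronger inhibitor, a higher number a weaker inhibitor), the highest of the three numbers measured so far. Compound 3 `Cc1ccc(NC2=CC(=O)c3c(nc4n3[C@H]3OC[C@@H](O)[C@H]3OC4)C2=O)cc1` gives 1550 nM in this assay, a gap from compound 2 that lies within the scatter, while compound 1 `Cc1ccc(NC2=CC(=O)c3c(nc4n3[C@H]3OC[C@@H](O)[C@H]3OC4)C2=O)cc1C` gives 1050 nM, a gap that lies beyond it. Compound 4 `O=C1C=C(Nc2cccc(F)c2)C(=O)c2c1nc1n2[C@H]2OC[C@@H](O)[C@H]2OC1` differs from compound 2 by 3-fluorophenyl in place of benzyl on an amine nitrogen. Within the data shown here, no measured step touches this change directly; the only single-point step, a 1.5-fold higher number from compound 1 to compound 3 (0.17 log units; within the scatter), concerns a methyl on an aromatic carbon and stays within the scatter. Still, in compounds 1 and 3 the aromatic ring sits on the amine nitrogen, as in compound 4, and both give lower numbers than compound 2, so a modest drop is expected. Compound 4 is therefore estimated at 1500 nM, within 700 nM to 3200 nM. The expected step, a 1.8-fold lower number from compound 2 to compound 4 (0.25 log units; within the scatter), would lie near the edge of the scatter.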

Compound 4, half-maximal inhibitory concentration: 2180 nM
Beside the measured number, compound 4's estimate is 1.5-fold (0.16 log units) below it; measured number inside the range.
By their numbers in this assay, from the lowest: compounds 1, 3, 4 and 2 (each within the scatter of the next, the first and the last beyond it).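

Swapping benzyl for 3-fluorophenyl on the amine nitrogen gives a 1.2-fold lower number from compound 2 to compound 4 (0.09 log units; within the scatter), the first measured step at this position. This exchange therefore produces no difference that can be told apart from the scatter in this assay. No supporting measurement bears on this result.

The swap both alters how the ring is joined to the nitrogen and adds fluorine, so the two contributions remain unseparated. An unsubstituted phenyl would separate them, while a longer chain such as phenethyl or a morpholine would test whether this position tolerates larger departures.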